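Removing a methyl from the cyanoguanidine tail of compound 1

The compounds below may be only part of what the source reports. "The series", "measured", "known", "first", "only" and "open" are said of these compounds alone.

Compound 1, `C/N=C(/NC#N)NCCCn1nc(-c2ccccc2)ccc1=O`, gives 40.5% in a functional assay on the whole organism with Rattus norvegicus as the target, at a dose of 100 mg/kg (a higher number here means more inhibition at the dose given (going by the name of the read-out), a lower number less inhibition), the highest of the three numbers measured. Compound 2, `C/N=C(/NC#N)NCCCn1nc(C)ccc1=O`, gives 6.8%, and compound 3, `C/N=C(/NC#N)NCCCn1nc(-c2ccccc2)c(C)cc1=O`, gives 17.2%. Both changes that were measured sit on the aromatic ring: a number 33.7 percentage points lower from compound 1 to compound 2 (beyond the scatter), and a number 23.3 percentage points lower from compound 1 to compound 3 (beyond the scatter). The untested compound 4, `N#CNC(=N)NCCCn1nc(-c2ccccc2)ccc1=O`, differs from compound 1 at the other end of the molecule: a group of 5 heavy atoms (2 carbon, 3 nitrogen; no ring) in place of a group of 6 heavy atoms (3 carbon, 3 nitrogen; no ring), on an amine nitrogen. For the measured compounds named here, neither measured step touches this tail, so there is no step that bears on the change directly; the ring changes only show that this series moves well beyond the scatter when altered. Without a guide, the expectation for compound 4 is a step in this assay of a number 4.5 percentage points lower from compound 1 to compound 4 (within the scatter), that is, no change beyond the scatter, with wide uncertainty. Compound 4 is therefore estimated at 36%, between 15% and 55%.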

Compound 4, a percentage reported as inhibition, in the whole organism at one dose (the size of the read-out at that dose, not a potency): 33.3%
Compound 4: middle estimate off by 2.7 percentage points, on the high side, within the range that was stated.
By their numbers in this assay, from the lowest: compound 2; then compound 3; then compounds 4 and 1 (each within the scatter of the next).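

In this assay, for the compounds shown here, the tail change on the amine nitrogen gives a number 7.2 percentage points lower from compound 1 to compound 4 (within the scatter), so it is the only measured step in this set that stays within the scatter, whereas both ring changes go beyond it. The swap also brings 2 hydrogen-bond donors in place of 1, yet at this single dose the read-out does not separate the two tails. No measurement at hand gives a reason for this result.

As far as these compounds go, what remains open is whether a larger group on that amine nitrogen, such as an ethyl or a benzyl, would keep the read-out at this level. From the compounds shown here alone, it is also open whether a longer chain between the tail and the shared core would do so, or whether this tail change behaves the same way alongside the ring changes of compound 2 and compound 3.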